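Chain shortening by one methyl on the aromatic amine substituent

The source may report more compounds than this note shows. Statements on the series, on what has been measured and on what is new or still open speak of the compounds shown alone.

Working notes on a small set of benzylamides built on a shared core. Compound 1 `CCCCCNc1nccnc1C(=O)NCc1ccccc1` carries a saturated chain on the ring nitrogen. In an ADME assay on HeLa cells (Homo sapiens) for cytotoxicity, read by microscopy, with a stated time of 6 days (on this read-out higher numbers stand for lower toxicity in this test and lower numbers for higher toxicity in this test), compound 1 gives only a limit of the test, > 100000 nM, not a number. That reading is the basis of the limit of > 100000 nM in this assay, at which 1 of the 3 values shown sits. Compound 2 `O=C(NCc1ccccc1)c1cncc(Cl)n1`, with a chlorine in place of the chain, has no result in this assay: "not determined" (no result reported). Compound 3 `CCCCCCCCNc1cnc(C(=O)NCc2ccccc2)cn1`, a longer-chain analogue on the same core, gives 100000 nM in this assay; both readings sit at or beyond the top of the test.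

Compound 4 `CCCCNc1nccnc1C(=O)NCc1ccccc1` is compound 1 with one change: hydrogen in place of methyl on a saturated chain carbon, four bonds along the chain from a nitrogen on an aromatic ring. Going by the values given here, no step between measured compounds is available to calibrate this change. With compound 1 already at the limit shown by the limit of > 100000 nM in this assay, at which 1 of the 3 values shown sits, no step beyond the scatter is expected for a number no higher from compound 1 to compound 4 (the limit leaves the size open) in this assay. Compound 4 is therefore estimated at 100000 nM in this assay, within 40000 nM to 100000 nM, most likely again as a limit rather than a number.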

Compound 4, minimum cytotoxic concentration: > 100000 nM
Compound 4 was reported as a limit (the forecaster's own chance of this, stated with the estimate: 70%); the middle value lies on the limit itself.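

Compound 1 and compound 4 both stand as limits in this assay, not as numbers, so no step can be read between them. The compounds shown leave open whether hydrogen in place of methyl on this chain changes the read-out at all.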